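This account rests on a few compounds, and the source may have more. Where it says the series, first, only, none or still open, it means among the compounds named here.

Measured so far in an assay (Cavia porcellus) for inhibition of Polyunsaturated fatty acid 5-lipoxygenase (Homo sapiens); on this read-out lower numbers stand for stronger inhibition and higher numbers for weaker inhibition:

compound 1 `NC(=O)N(O)CC1=Cc2cc(OCc3ccccc3)ccc2OC1`: 380 nM
compound 2 `CCCCCCOc1ccc2c(c1)C=C(CN(O)C(N)=O)CO2`: 340 nM
compound 3 `NC(=O)N(O)CC1=Cc2cc(OCC3CCCCC3)ccc2OC1`: 1390 nM

Compound 3 stands at the highest number of the three, with a 3.7-fold higher number from compound 1 to compound 3 (0.56 log units; beyond the scatter) and a 4.1-fold higher number from compound 2 to compound 3 (0.61 log units; beyond the scatter); the two lower values sit together, since a 1.1-fold lower number from compound 1 to compound 2 (0.05 log units; within the scatter).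

The next compound is compound 4 `NC(=O)N(O)CC1=Cc2cc(OCCCc3ccccc3)ccc2OC1`. It differs from compound 3 as follows: phenethyl in place of cyclohexyl on a saturated chain carbon bound to an oxygen on an aromatic ring.

Going by the values given here, two measured steps bear on this change, both arriving at compound 3 from a compound in which the group on that chain carbon is either an aromatic ring (phenyl) or an open chain (pentyl). In each case cyclohexyl brought a modest rise in the number, beyond the scatter. Compound 4 removes the cyclohexyl again and puts back an aromatic ring, now on a longer chain. Among the compounds with values here, no measured pair tests the extra chain length directly, so the chain-length part of the change is uncharted. On the basis of compound 1 and compound 2 the expected step is a 3.1-fold lower number from compound 3 to compound 4 (0.49 log units; beyond the scatter), a fall back toward their range. Compound 4 is therefore estimated at 450 nM, with a range of 150 nM to 1400 nM.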

Compound 4, half-maximal inhibitory concentration: 160 nM
Compound 4: the middle estimate sits 2.8-fold (0.45 log units) above what was measured; the range from low to high includes it.
By their numbers in this assay, from the lowest: compound 4; then compounds 2 and 1 (each within the scatter of the next); then compound 3.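

In this assay, going by these compounds alone, phenethyl is the first group at this position to give a number below the level shared by the phenyl and pentyl groups, and it also reverses the loss seen with cyclohexyl, with an 8.7-fold lower number from compound 3 to compound 4 (0.94 log units; beyond the scatter). The added chain length on the aromatic ring counts for something here, with a 2.4-fold lower number from compound 1 to compound 4 (0.38 log units; beyond the scatter), a step modest in size but beyond the scatter. The aromatic ring at the chain end also counts, since phenyl in place of propyl, three bonds along the chain from the oxygen on the aromatic ring, gives a 2.1-fold lower number from compound 2 to compound 4 (0.33 log units; beyond the scatter).

No measurement available here explains these steps. Still open, from the compounds shown here alone, is whether a longer chain ending in phenyl lowers the number further, and whether an amine or a carboxylic acid at the chain end is compatible with this result.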